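From Ethyl to Propyl: a Chain Grows by a Methyl

This account rests on a few compounds, and the source may have more. Where it says the series, first, only, none or still open, it means among the compounds named here.

Three compounds share one core and differ only in the group on one aromatic carbon. In an assay on membranes from brain for displacement of a labelled ligand from Neuronal acetylcholine receptor; alpha4/beta2 (Rattus norvegicus) (a higher number here means a weaker inhibitor, a lower number a stronger inhibitor), compound 1 `CN1CCC[C@H]1COc1cncc(C(F)(F)F)c1`, carrying trifluoromethyl, gives 1.83 nM. Compound 2 `CN1CCC[C@H]1COc1cncc(Br)c1`, with bromo, gives 0.27 nM, and compound 3 `CCc1cncc(OC[C@@H]2CCCN2C)c1`, with ethyl, gives 0.32 nM. The two measured changes from compound 1 are a 6.8-fold lower number from compound 1 to compound 2 (0.83 log units; beyond the scatter) and a 5.7-fold lower number from compound 1 to compound 3 (0.76 log units; beyond the scatter), while the change between the other two is a 1.2-fold higher number from compound 2 to compound 3 (0.07 log units; within the scatter). Compound 3 thus sits together with compound 2, well apart from compound 1.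

Compound 4 `CCCc1cncc(OC[C@@H]2CCCN2C)c1` extends the ethyl: methyl in place of hydrogen on a saturated chain carbon, two bonds along the chain from an aromatic carbon. Among the measured compounds shown here, no measured step grows a chain in this way; the steps seen so far swap the whole group on the aromatic carbon, and the two groups without fluorine came out alike. With nothing in the data to suggest a large effect, the expected step is a 1.4-fold higher number from compound 3 to compound 4 (0.15 log units; within the scatter), small and within or near the scatter. Compound 4 is therefore estimated at 0.45 nM, with a range from 0.15 nM to 1.5 nM.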

Compound 4, inhibition constant: 0.12 nM
Compound 4: middle estimate off by 3.8-fold (0.57 log units), on the high side; measured number below the stated range.
By their numbers in this assay, from the lowest: compound 4; then compounds 2 and 3 (each within the scatter of the next); then compound 1.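

Unlike the earlier steps, which swapped the whole group on the aromatic carbon, this one only lengthens a chain, and growing ethyl to propyl gives a 2.7-fold lower number from compound 3 to compound 4 (0.43 log units; beyond the scatter) in this assay, so a single added methyl at this place is enough to register. Propyl also separates from bromo, with a 2.3-fold lower number from compound 2 to compound 4 (0.35 log units; beyond the scatter) where ethyl did not, and against trifluoromethyl the gap reaches a 15-fold lower number from compound 1 to compound 4 (1.18 log units; beyond the scatter) in the same assay, which makes compound 4 the strongest of the four here. Nothing available explains why the added methyl has this effect.

On these data alone, whether the numbers keep falling with a longer chain such as butyl remains open. So does the outcome for a branched group such as isopropyl, or for a propyl chain ending in a hydroxyl group.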